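Swapping the stereocentre in the imidazole-bearing acylguanidine

A few compounds are considered here, and "the series" means these few. Any claim that something is new, unique, unknown or untested is made for them only; others in the source may bear on it.

Four acylguanidines share one chain with a branched carbon carrying a phenyl ring, and were compared in an in vitro functional assay on Sf9 cells for agonist activity at histamine H2 receptor (Cavia porcellus), read by GTPgammaS binding; on this read-out higher numbers stand for an effect only at larger amounts of compound and lower numbers for an effect already at smaller amounts. Compound 1 `Cc1nc(N)sc1CCCNC(=N)NC(=O)C[C@@H](C)c1ccccc1` gives 17 nM, compound 3 `Cc1nc(N)sc1CCCNC(=N)NC(=O)CC(C)c1ccccc1` gives 22.4 nM, and compound 2 `C[C@H](CC(=O)NC(=N)NCCCc1c[nH]cn1)c1ccccc1` gives 75.9 nM, the highest of the three numbers. The step of a 1.3-fold higher number from compound 1 to compound 3 (0.12 log units; within the scatter) stays within the scatter, and the only structural difference there is the fact that one of compounds 1 and 3 is drawn with a defined configuration and the other without, at the place where they differ. The step of a 4.5-fold higher number from compound 1 to compound 2 (0.65 log units; beyond the scatter) is modest but beyond the scatter. Compound 4 `C[C@@H](CC(=O)NC(=N)NCCCc1c[nH]cn1)c1ccccc1` differs from compound 2 only in that (the two compounds have the same atoms and bonds; at least one stereo element is drawn with a configuration in one of them and without one in the other: 1 of 2 stereo elements differ; a stereocentre at a saturated chain carbon is drawn R in compound 2 and S in compound 4). For the measured compounds named here, the one measured step that bears on the stereocentre, from compound 1 to compound 3, was within the scatter, so the expectation for this assay is a small step, if any, most likely towards a somewhat higher number, as a 1.4-fold higher number from compound 2 to compound 4 (0.16 log units; within the scatter). Compound 4 is therefore estimated at 110 nM, with a range from 35 nM to 350 nM.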

Compound 4, half-maximal effective concentration: 24 nM
For compound 4 the middle estimate is 4.6-fold (0.66 log units) above the measured one; measured number below the stated range.
By their numbers in this assay, from the lowest: compounds 1, 3 and 4 (each within the scatter of the next); then compound 2.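

In this assay the stereocentre at the saturated chain carbon turns out to matter, with a 3.2-fold lower number from compound 2 to compound 4 (0.50 log units; beyond the scatter). The earlier 1.3-fold higher number from compound 1 to compound 3 (0.12 log units; within the scatter) set a centre drawn R against one drawn without a configuration, so only now do R and S stand directly against each other, and S carries the lower number, an effect already at smaller amounts. The step can be put down to this centre alone because the two compounds differ in one respect only: the fact that one of compounds 2 and 4 is drawn with a defined configuration and the other without, at the place where they differ

As far as these compounds go, with the 2-amino-4-methyl-1,3-thiazol-5-yl group only the R form and the undefined form appear, so whether S also gives a lower number there stays open. Equally open, from the compounds shown here alone, is whether a gap between R and S would persist with an ethyl group at the stereocentre or a cyclohexyl ring in place of the phenyl ring.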